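Alkoxy variation on the shared core: compound 2 to compound 4

A few compounds are considered here, and "the series" means these few. Any claim that something is new, unique, unknown or untested is made for them only; others in the source may bear on it.

Compound 2, `O=C(/C=C/c1ccc(O)cc1)c1c(O)cccc1OCc1ccccc1`, belongs to a small set of analogues tested in a functional assay on PC-3 cells (Homo sapiens) for antiproliferative activity, read by sulforhodamine B assay; a lower number here means a stronger inhibitor of growth, a higher number a weaker inhibitor of growth. In this assay compound 2 gives only a limit, > 30000 nM. Compound 1, `COc1cccc(OCCC(C)(C)C)c1C(=O)/C=C/c1ccc(O)cc1`, likewise returns only the limit, > 30000 nM. Compound 3, `CC(C)(C)CCOc1cccc(O)c1C(=O)CCc1ccc(O)cc1`, also sits at the limit, > 30000 nM. Among the measured compounds shown here, the whole set therefore rests on (the limit of > 30000 nM in this assay, at which 3 of the 3 values shown sit), and no compound yet yields a number. Compound 4, `CCC(CC)COc1cccc(O)c1C(=O)/C=C/c1ccc(O)cc1`, is the next candidate; relative to compound 2 the change is pentan-3-yl in place of phenyl on a saturated chain carbon bound to an oxygen on an aromatic ring. For the measured compounds named here, no measured pair of this set differs in one place, so no measured step guides the expectation. Going by the values given here, because the limit of > 30000 nM in this assay, at which 3 of the 3 values shown sit, holds for every compound so far, compound 4 is expected to show no step beyond the scatter, a number no higher from compound 2 to compound 4 (the limit leaves the size open). Compound 4 is thus estimated at 30000 nM, between 10000 nM and 100000 nM.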

Compound 4, concentration for 50% growth inhibition: 3390 nM
Compound 4: the middle estimate sits 8.8-fold (0.95 log units) above what was measured; measured number below the stated range.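

In this assay, pentan-3-yl in place of phenyl on a saturated chain carbon bound to an oxygen on an aromatic ring gives an at least 8.8-fold lower number from compound 2 to compound 4 (0.94 log units; beyond the scatter). Among the compounds shown here, this is the first sign that this position affects growth inhibition, and compound 4 is the first compound to give a number rather than a limit. On these data alone, the true size of the step stays unknown, as compound 2 gives only a limit, > 30000 nM.

As far as these compounds go, whether the gain follows from losing the aromatic ring or from the branched chain remains open. Cyclohexyl or a straight pentyl chain in the same place would separate the two.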